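The source may report more compounds than this note shows. Statements on the series, on what has been measured and on what is new or still open speak of the compounds shown alone.

Working notes on the series. Compound 1 `COc1cc2c(Nc3ccc(C#N)cc3)ncnc2cc1OCCCN1CCC(O)CC1`, compound 2 `COc1cc2c(Nc3ccc(C#N)cc3)ncnc2cc1OCCCN1CCC(CO)CC1` and compound 3 `CCOC(=O)C1CCN(CCCOc2cc3ncnc(Nc4ccc(C#N)cc4)c3cc2OC)CC1` share one core and differ only in the substituent on a saturated ring carbon. In a functional assay on MCF7 cells (Homo sapiens) for antiproliferative activity, read by MTT assay, with a stated time of 72 h (a higher number here means a weaker inhibitor, a lower number a stronger inhibitor), compound 1 gives > 100000 nM, which is a limit of the assay and not a number. In this assay compound 2 gives 35100 nM. In this assay compound 3 gives 34900 nM. The steps of an at least 2.8-fold lower number from compound 1 to compound 2 (0.45 log units; beyond the scatter) and an at least 2.8-fold lower number from compound 1 to compound 3 (0.45 log units; beyond the scatter) are each at least modest and move away from the limit (the limit of > 100000 nM in this assay, at which 1 of the 3 values shown sits); the step of a 1.0-fold lower number from compound 2 to compound 3 (0.00 log units; within the scatter) lies within the scatter. Of the two numbers shown, compound 3 stands lowest, with compound 2 within the scatter of it, and the one further value is a limit only.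

Compound 4 `COc1cc2c(Nc3ccc(C#N)cc3)ncnc2cc1OCCCN1CCN(c2ccncc2)CC1` has not yet been measured. Its change from compound 3 is 4-(pyridin-4-yl)piperazin-1-yl in place of 4-(ethoxycarbonyl)piperidin-1-yl on a saturated chain carbon, three bonds along the chain from an oxygen on an aromatic ring. Going by the values given here, no measured step bears directly on this change: each of them swaps a substituent on a saturated ring carbon while the ring itself stays, whereas here the whole group leaves. Among the compounds with values here, the steps of an at least 2.8-fold lower number from compound 1 to compound 2 (0.45 log units; beyond the scatter) and an at least 2.8-fold lower number from compound 1 to compound 3 (0.45 log units; beyond the scatter) were at least modest; the single step between two numbers, a 1.0-fold lower number from compound 2 to compound 3 (0.00 log units; within the scatter), showed no change. For compound 4 the expected step is therefore a 1.4-fold lower number from compound 3 to compound 4 (0.14 log units; within the scatter) in this assay, not beyond the scatter, either direction possible. The estimate for compound 4 in this assay is 25000 nM, with a range from 5000 nM to 100000 nM.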

Compound 4, half-maximal inhibitory concentration: 22900 nM
Beside the measured number, compound 4's estimate is 1.1-fold (0.04 log units) above it; the measured number falls inside the stated range.
By their numbers in this assay, from the lowest: compounds 4, 3 and 2 (each within the scatter of the next). At a limit, above all of these: compound 1.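

In this assay, the group on the saturated chain carbon, three bonds along the chain from an oxygen on an aromatic ring, can be exchanged whole with no change beyond the scatter: the steps are a 1.5-fold lower number from compound 3 to compound 4 (0.18 log units; within the scatter) and a 1.5-fold lower number from compound 2 to compound 4 (0.19 log units; within the scatter). Going by these compounds alone, the earlier steps only swapped a substituent on a saturated ring carbon while the ring stayed, so 4-(pyridin-4-yl)piperazin-1-yl, which brings a second ring, is the first reading on this kind of replacement, and it stands level with 4-(ethoxycarbonyl)piperidin-1-yl and 4-(hydroxymethyl)piperidin-1-yl. Against 4-hydroxypiperidin-1-yl the step is an at least 4.3-fold lower number from compound 1 to compound 4 (0.64 log units; beyond the scatter), which is at least modest and is read from a limit, not a number: the limit of > 100000 nM in this assay, at which 1 of the 4 values shown sits.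

The compounds shown leave open whether a carboxylic acid in place of the ethoxycarbonyl, or a morpholine or an open-chain dimethylamine in place of the whole ring, would stay within the scatter of compound 4. They also leave open whether a longer chain, or a group other than the nitrile on the shared core, would move the number beyond the scatter.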